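A few compounds are considered here, and "the series" means these few. Any claim that something is new, unique, unknown or untested is made for them only; others in the source may bear on it.

Three compounds have been measured in a functional assay on HCT-116 cells (Homo sapiens), read by MTT assay, with a stated time of 72 h; on this read-out higher numbers stand for weaker inhibition and lower numbers for stronger inhibition:

compound 1, `COc1ncnc2c1c(I)cn2[C@@H]1O[C@H](CO)[C@@H](O)[C@H]1O`: > 20000 nM, a limit of the assay rather than a number
compound 2, `CNc1ncnc2c1c(-c1ccsc1)cn2[C@@H]1O[C@H](CO)[C@@H](O)[C@H]1O`: > 20000 nM, likewise a limit
compound 3, `CNc1ncnc2c1c(-c1ccoc1)cn2[C@@H]1O[C@H](CO)[C@@H](O)[C@H]1O`: > 20000 nM, likewise a limit

For the measured compounds named here, compound 3 therefore stands only at a limit in this assay, and the two further values shown are limits as well, so no compound among the three can be set above or below another. Going by the values given here, the one step between measured compounds that differ in a single place, a step that the two limits leave unreadable from compound 2 to compound 3, is left unreadable by the two limits, and the same holds for any comparison with compound 1, whose value is also a limit. Among the compounds with values here, the only evidence on the measured steps is the limit of > 20000 nM in this assay, at which 3 of the 3 values shown sit.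

Compound 4, `CNc1ncnc2c1c(I)cn2[C@@H]1O[C@H](CO)[C@@H](O)[C@H]1O`, is not yet measured. It differs from compound 3 in one place: iodo in place of furan-3-yl on an aromatic carbon. Compound 1 already carries iodo on the same carbon of the shared core and sits at the limit, and compound 3 with furan-3-yl sits at the limit too. Within the data shown here, since no measured step bears readably on this change, the step that the limit leaves unreadable from compound 3 to compound 4 is expected to be none beyond the scatter, with compound 4 expected to remain at the limit. Compound 4 is accordingly estimated at 30000 nM, within 15000 nM to 100000 nM.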

Compound 4, half-maximal inhibitory concentration: > 100000 nM
Compound 4 ended at the assay's limit (the forecaster's own chance of this, stated with the estimate: 90%); middle value at least 3.3-fold (0.52 log units) from the limit.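

In this assay compound 4 gives > 100000 nM, which is a limit of the assay and not a number. Compound 1, compound 2 and compound 3 also stand only at limits, so none of the steps to compound 4 can be read. The compounds shown leave open whether iodo, furan-3-yl, thiophen-3-yl, methoxy or methylamino on the shared core makes any difference in this assay.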